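Trimethoxyphenyl in place of phenylethenyl: what to expect

A few compounds are considered here, and "the series" means these few. Any claim that something is new, unique, unknown or untested is made for them only; others in the source may bear on it.

Compound 1 `Cc1cc(O)c(C2=NN(c3ccc(S(N)(=O)=O)cc3)C(c3ccccc3O)C2)cc1Cl` gives 9330 nM in a functional assay on PC-3 cells (Homo sapiens) for antiproliferative activity, with a stated time of 48 h; a lower number here means that less compound is tolerated, a higher number that more compound is tolerated. Compound 2 `Cc1cc(O)c(C2=NN(c3ccc(S(N)(=O)=O)cc3)C(/C=C/c3ccccc3)C2)cc1Cl` gives 34000 nM. Compound 3 `COc1ccc(C2CC(c3cc(Cl)c(C)cc3O)=NN2c2ccc(S(N)(=O)=O)cc2)cc1OC` reaches only the limit of > 100000 nM, a limit of this assay and not a number.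

Of the two numbers, compound 2 holds the higher one; its nearest neighbour is compound 1, with a 3.6-fold higher number from compound 1 to compound 2 (0.56 log units; beyond the scatter). Compound 4 `COc1ccc(C2CC(c3cc(Cl)c(C)cc3O)=NN2c2ccc(S(N)(=O)=O)cc2)c(OC)c1OC` differs from compound 2 by 2,3,4-trimethoxyphenyl in place of 2-phenylethenyl on a saturated ring carbon. The step that bears on this change is an at least 2.9-fold higher number from compound 2 to compound 3 (0.46 log units; beyond the scatter), where the dimethoxyphenyl analogue ran into the limit (the limit of > 100000 nM in this assay, at which 1 of the 3 values shown sits); the related step of an at least 10-fold higher number from compound 1 to compound 3 (1.03 log units; beyond the scatter) ended there as well. A third methoxy group is a small further change, so compound 4 is expected to move up beyond the scatter, a 2.9-fold higher number from compound 2 to compound 4 (0.47 log units; beyond the scatter), quite possibly to the limit. Compound 4 is therefore estimated at 100000 nM, within 30000 nM to 300000 nM.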

Compound 4, concentration lethal to 50% of the cells: 40100 nM
For compound 4 the middle estimate is 2.5-fold (0.40 log units) above the measured one; the range from low to high includes it.
By their numbers in this assay, from the lowest: compound 1; then compounds 2 and 4 (each within the scatter of the next). At a limit, above all of these: compound 3.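

On this saturated ring carbon, 2,3,4-trimethoxyphenyl and 2-phenylethenyl cannot be told apart in this assay (a 1.2-fold higher number from compound 2 to compound 4 (0.07 log units; within the scatter)), while 2-hydroxyphenyl remains separate from the former (a 4.3-fold higher number from compound 1 to compound 4 (0.63 log units; beyond the scatter)). One further methoxy group does not push the number on up the scale, as the step read from a limit shows: an at least 2.4-fold lower number from compound 3 to compound 4 (0.39 log units; beyond the scatter). Compound 3 stands at a limit and not at a number: the limit of > 100000 nM in this assay, at which 1 of the 4 values shown sits.

On these data alone, what a carboxylic acid or an amine on this saturated ring carbon would give stays open. So does the effect of a plain methyl group there.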